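Iodoacetyl-tethered nucleotide analogues, hexokinase inhibition series

The source may hold more compounds than are shown below. What is called first, only, known or untested is meant among the compounds shown, and "the series" means these compounds.

Compound 1 `CN(CCCN(C)C(=O)CCCCNc1ncnc2c1ncn2[C@@H]1O[C@H](COP(=O)(O)OP(=O)(O)OP(=O)(O)O)[C@@H](O)[C@H]1O)C(=O)CCCCNC(=O)CI` carries a long branched tether ending in an iodoacetamide. In an assay on isolated protein for inhibition of hexokinase-1 (Rattus norvegicus), with a stated time of 6 h, tested at 10 mM (a lower number here means less inhibition, a higher number more inhibition at the concentration tested (going by the name of the read-out)), compound 1 gives 0%. Compound 2 `O=C(CI)NCCCC(=O)NCCCCCCNc1ncnc2c1ncn2[C@@H]1O[C@H](COP(=O)(O)OP(=O)(O)OP(=O)(O)O)[C@@H](O)[C@H]1O` has a shorter, linear tether to the same shared core. In this assay compound 2 gives 0%. Compound 2 stands level with compound 1 at the digits shown; the nearest measured neighbour is compound 1, and the two values do not differ beyond the scatter, so no order between them can be stated.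

Compound 3 `O=C(I)NCC(=O)NCCCCCCNc1ncnc2c1ncn2[C@@H]1O[C@H](COP(=O)(O)OP(=O)(O)OP(=O)(O)O)[C@@H](O)[C@H]1O` shortens the tether of compound 2 further. The change from compound 2 to compound 3 is a group of 4 heavy atoms (1 carbon, 1 nitrogen, 1 oxygen, 1 iodine; no ring) in place of a group of 7 heavy atoms (4 carbon, 1 nitrogen, 1 oxygen, 1 iodine; no ring), on a saturated chain carbon bound to a carbonyl carbon.

Among the measured compounds shown here, no step between measured compounds is available for this change, and both measured compounds show no inhibition at the tested concentration. Nothing in the data points to a step in either direction for compound 3, so the expected step is none beyond the scatter. The expected step of no change at the digits printed from compound 2 to compound 3 (within the scatter) is estimated as flat. Compound 3 is expected to give 0%, with a range from 0% to 10%.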

Compound 3, a percentage reported as inhibition, at one concentration (the size of the read-out at that concentration, not a potency): 0%
For compound 3 middle estimate and measured number coincide at the digits printed; low and high end bracket the measured number.
By their numbers in this assay, from the lowest: compounds 1, 2 and 3 (each within the scatter of the next).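

In this assay, among the compounds shown here, replacing the 2-(((iodomethyl)carbonyl)amino)ethyl group, on a saturated chain carbon bound to a carbonyl carbon, with the group of 4 heavy atoms gives no change at the digits printed from compound 2 to compound 3 (within the scatter) and is the first step that can be read at this position. Thus, a smaller group here, still with 1 iodine and 1 hydrogen-bond donor, leaves the read-out where compound 2 had it, and compound 3 records 0% at the single tested concentration. No available evidence bears on this result.

With no inhibition recorded for any of the three compounds, the series gives no reference point showing how far a change at this position could move the read-out, and a real difference too small to appear at this concentration cannot be excluded. A longer chain, or an amine or a carboxylic acid in place of the iodine-bearing end, would test whether any group at this position produces inhibition in this assay at all.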